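Predicting Compound 3 from Two Measured Analogues

The compounds below may be only part of what the source reports. "The series", "measured", "known", "first", "only" and "open" are said of these compounds alone.

Of the compounds shown here, two that share one core have been tested in a functional assay on the whole organism (strain BALB/c) with Mus musculus as the target, with a stated time of 8 h, at a dose of 10 mg/kg; on this read-out higher numbers stand for more inhibition at the one dose given (going by the name of the read-out) and lower numbers for less inhibition. Compound 1 `Cc1ccc(NC(=O)CN2C(=O)NC3(CCCCC3)C2=O)cc1` gives 70.3%, and compound 2 `COc1ccc(NC(=O)CN2C(=O)NC3(CCCCC3)C2=O)cc1` gives 56.1%. Among the measured compounds shown here, the only change between them, methoxy in place of methyl on an aromatic carbon, produced a number 14.2 percentage points lower from compound 1 to compound 2 (beyond the scatter). Compound 2 therefore stands lowest of the two numbers, with compound 1 as its nearest and higher neighbour.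

Compound 3 `O=C(CN1C(=O)NC2(CCCCC2)C1=O)Nc1ccc(Cl)cc1Cl` has not yet been measured in this assay. It differs from compound 2 by 2,4-dichlorophenyl in place of 4-methoxyphenyl on an amide-type nitrogen. For the measured compounds named here, no measured step involves a chlorine-bearing ring, so the only guide is that one change on this aromatic ring moved the number by a modest amount from compound 1 to compound 2. A step of similar size in either direction, or none beyond the scatter, seems possible for compound 3, and the expected change is a number 3.9 percentage points higher from compound 2 to compound 3 (within the scatter). On that basis compound 3 is estimated to give 60%, with a likely range from 35% to 85%.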

Compound 3, a percentage reported as inhibition, in the whole organism at one dose (the size of the read-out at that dose, not a potency): 68.5%
Estimate against measurement, compound 3: 8.5 percentage points below; low and high end bracket the measured number.
By their numbers in this assay, from the lowest: compound 2; then compounds 3 and 1 (each within the scatter of the next).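

In this assay, 2,4-dichlorophenyl in place of 4-methoxyphenyl on the amide-type nitrogen gives a number 12.4 percentage points higher from compound 2 to compound 3 (beyond the scatter), so this position can respond to the choice of ring in the upward direction as well as the downward one seen earlier. With 2,4-dichlorophenyl in place of 4-methylphenyl at the same nitrogen, the result is a number 1.8 percentage points lower from compound 1 to compound 3 (within the scatter) and the two rings cannot be told apart here, leaving compound 2, the only one of the three with a methoxy group and a hydrogen-bond acceptor on this ring, lower than both of the others. No measurement is available that would explain these differences.

The compounds shown leave open whether both chlorines are needed, since a ring with a single chlorine, a plain phenyl ring or a ring carrying an amine or a carboxylic acid would each test a different part of this picture. On these data alone, all three compounds also share the same core and were compared at one dose, so how far these steps carry over to other cores or other doses remains open.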